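The source may hold more compounds than are shown below. What is called first, only, known or untested is meant among the compounds shown, and "the series" means these compounds.

Measured in a functional assay on MDA-MB-231 cells (Homo sapiens) for inhibition, read by MTT assay, with a stated time of 72 h; a lower number here means a stronger inhibitor, a higher number a weaker inhibitor:
Compound 1 `CC(C)(C)n1cc2c(n1)C(=O)CC1(CCN(C(=O)c3cc(-c4ccc(Cl)cc4)nc4ccccc34)CC1)O2`: > 10000 nM
Compound 2 `CC(C)(C)n1cc2c(n1)C(=O)CC1(CCN(C(=O)c3cc(-c4ccc(Br)cc4)nc4ccccc34)CC1)O2`: > 10000 nM

Compound 1 stands at > 10000 nM, which is a limit of this assay and not a number. Compound 2 stands at > 10000 nM, which is likewise a limit. Neither compound therefore has a readable potency, and the whole measured record comes to this: the limit of > 10000 nM in this assay, at which 2 of the 2 values shown sit.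

Compound 3 `COc1ccc(-c2cc(C(=O)N3CCC4(CC3)CC(=O)c3nn(C(C)(C)C)cc3O4)c3ccccc3n2)cc1OC` keeps the shared core and carries 3,4-dimethoxyphenyl in place of 4-bromophenyl on an aromatic carbon, next to the ring nitrogen: 3,4-dimethoxyphenyl in place of 4-bromophenyl on an aromatic carbon.

Within the data shown here, only one measured step touches this aryl group, the swap of bromo in place of chloro on an aromatic carbon. That is a step that the two limits leave unreadable from compound 1 to compound 2, so it offers no size to carry over and no direction. Among the measured compounds shown here, the new substituents also have no measured precedent in this small set. The expected change is therefore a step that the limit leaves unreadable from compound 2 to compound 3, a cautious estimate with little data behind it.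

For compound 3 the estimate in this assay is 12000 nM, with an expected range from 3000 nM to 40000 nM.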

Compound 3, half-maximal inhibitory concentration: 7130 nM
Beside the measured number, compound 3's estimate is 1.7-fold (0.23 log units) above it; the measured number falls inside the stated range.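

In this assay, among these compounds, compound 3 gives 7130 nM, the first reading in this set that is a number. The readings of compound 1 and compound 2 are limits, so the aryl group on the aromatic carbon next to the ring nitrogen is a place where a single change can bring the reading off that limit. Going by these compounds, both steps are only floors: 3,4-dimethoxyphenyl in place of 4-bromophenyl gives an at least 1.4-fold lower number from compound 2 to compound 3 (0.14 log units; that floor lies within the scatter), and 3,4-dimethoxyphenyl in place of 4-chlorophenyl gives an at least 1.4-fold lower number from compound 1 to compound 3 (0.14 log units; that floor lies within the scatter), so the true size of the change remains unknown and these floors alone establish no difference beyond the scatter. The rest of the record remains a limit and not a number: the limit of > 10000 nM in this assay, at which 2 of the 3 values shown sit.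

The compounds shown do not tell whether both methoxy groups are needed for the reading of compound 3, since a single methoxy group at either of these ring positions does not appear among them. They also leave open how a hydroxyl group, a dimethylamino group or a longer alkoxy chain on this phenyl ring would read in this assay.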